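The compounds below may be only part of what the source reports. "The series", "measured", "known", "first", "only" and "open" are said of these compounds alone.

In a functional assay on UACC-62 cells (Homo sapiens) (a higher number here means a weaker inhibitor of growth, a lower number a stronger inhibitor of growth), compound 1 (`N#Cc1ccc(/C=C/S(=O)(=O)Cc2ccc(Nc3ncnc4ccccc34)cc2)cc1`) gives > 100000 nM, which is a limit of the assay and not a number. Compound 2 (`O=S(=O)(/C=C/c1ccc(F)cc1F)Cc1ccc(Nc2ncnc3ccccc23)cc1`) gives > 100000 nM, also only a limit. The picture so far is the limit of > 100000 nM in this assay, at which 2 of the 2 values shown sit. Compound 3 (`O=S(=O)(/C=C/c1ccc(F)cc1F)Cc1ccc(Nc2ncnc3ccc(Br)cc23)cc1`) keeps everything in compound 2 except for bromo in place of hydrogen on an aromatic carbon of the shared core: bromo in place of hydrogen on an aromatic carbon. Among the measured compounds shown here, the one measured step is a step that the two limits leave unreadable from compound 1 to compound 2. It exchanges 4-cyanophenyl for 2,4-difluorophenyl, has no readable size and does not involve bromo, so it sets no size for this change. At most a modest move towards stronger growth inhibition is expected, and the assay may well report a limit again. The expected step is an at least 1.2-fold lower number from compound 2 to compound 3 (0.09 log units; that floor lies within the scatter). For compound 3 the estimate is 80000 nM, with an expected range from 15000 nM to 100000 nM.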

Compound 3, concentration for 50% growth inhibition: 3000 nM
Beside the measured number, compound 3's estimate is 27-fold (1.43 log units) above it, and the stated range ends above it.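

In this assay, bromo in place of hydrogen gives an at least 33-fold lower number from compound 2 to compound 3 (1.52 log units; beyond the scatter), which makes this aromatic carbon of the shared core, meta to a fused ring and para to a fused ring, the first place shown where a single change yields a readable number. The value of compound 2, > 100000 nM, is a limit of the assay and not a number, so the size of this step is only a floor. The earlier exchange of 4-cyanophenyl for 2,4-difluorophenyl cannot be read, and only compound 3 stands off the limit: the limit of > 100000 nM in this assay, at which 2 of the 3 values shown sit.

The compounds shown leave open whether chloro, methyl or an amine on the same aromatic carbon would lower the number as bromo does. They also leave open whether bromo would give a similar step with 4-cyanophenyl in place of 2,4-difluorophenyl, as the step is seen on one background only.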